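Methyl Added on the Glycine Carbon: Cytotoxicity Expectation

The source may report more compounds than this note shows. Statements on the series, on what has been measured and on what is new or still open speak of the compounds shown alone.

Compound 1 `Cc1cc(C)cc(S(=O)(=O)c2c(C(=O)NCC(=O)NCc3ccncc3)[nH]c3ccc(Cl)cc23)c1` carries a (pyridin-4-yl)methyl group on the outer amide nitrogen. In an ADME assay on MT4 cells (Homo sapiens) for cytotoxicity, read by MTT assay (on this read-out lower numbers stand for higher toxicity in this test and higher numbers for lower toxicity in this test), compound 1 gives only a limit of the test, > 48900 nM. Compound 2 `Cc1cc(C)cc(S(=O)(=O)c2c(C(=O)NCC(=O)NC(C)c3ccncc3)[nH]c3ccc(Cl)cc23)c1` differs by methyl in place of hydrogen on a saturated chain carbon bound to an amide-type nitrogen and an aromatic carbon, and in this assay compound 2 gives 47000 nM; the step of an at least 1.0-fold lower number from compound 1 to compound 2 (0.01 log units; that floor lies within the scatter) cannot be separated from repeat scatter. Compound 3 `Cc1cc(C)cc(S(=O)(=O)c2c(C(=O)NCC(=O)NC(C)c3ccccc3F)[nH]c3ccc(Cl)cc23)c1` replaces the pyridine-bearing side chain, (1-(2-fluorophenyl)ethyl in place of (pyridin-4-yl)methyl on an amide-type nitrogen), and in this assay compound 3 gives 23000 nM; the steps of an at least 2.1-fold lower number from compound 1 to compound 3 (0.32 log units; beyond the scatter) and a 2.0-fold lower number from compound 2 to compound 3 (0.31 log units; beyond the scatter) are both beyond scatter. One value sits at the limit (the limit of > 48900 nM in this assay, at which 1 of the 3 values shown sits).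

Compound 4 `Cc1cc(C)cc(S(=O)(=O)c2c(C(=O)NC(C)C(=O)NC(C)c3ccccc3F)[nH]c3ccc(Cl)cc23)c1` is not yet measured. It differs from compound 3 by methyl in place of hydrogen on a saturated chain carbon bound to an amide-type nitrogen and a carbonyl carbon. This is the same kind of change as methyl in place of hydrogen on a saturated chain carbon bound to an amide-type nitrogen and an aromatic carbon, but the place differs: there the carbon is bound to an aromatic carbon, here to a carbonyl carbon. The earlier step, an at least 1.0-fold lower number from compound 1 to compound 2 (0.01 log units; that floor lies within the scatter), was within scatter, and the core difference is 1-(2-fluorophenyl)ethyl in place of (pyridin-4-yl)methyl on an amide-type nitrogen. Compound 4 is therefore expected to move little, a 1.2-fold lower number from compound 3 to compound 4 (0.06 log units; within the scatter), resting on that earlier step. The estimate for compound 4 in this assay is 20000 nM, spanning 9000 nM to 45000 nM.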

Compound 4, half-maximal cytotoxic concentration: 15200 nM
The estimate for compound 4 lay 1.3-fold (0.12 log units) above the measured number; the range from low to high includes it.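

In this assay, methyl in place of hydrogen on a saturated chain carbon bound to an amide-type nitrogen and a carbonyl carbon gives a 1.5-fold lower number from compound 3 to compound 4 (0.18 log units; within the scatter), a step that cannot be separated from repeat scatter. Set beside the earlier methyl step, which sits on a chain carbon bound to an aromatic carbon, this result does not show that the change carries from one core to another with the same size, nor that it carries differently: the same change on two cores in this assay, an at least 1.0-fold lower number (0.01 log units; that floor lies within the scatter) from compound 1 to compound 2 and a 1.5-fold lower number (0.18 log units; within the scatter) from compound 3 to compound 4; the limit leaves it open whether they differ. Compound 1 gives a limit and not a number, so the earlier step is only a floor: the limit of > 48900 nM in this assay, at which 1 of the 4 values shown sits.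

The compounds shown leave open how an ethyl group or a longer chain on the same carbon would read in this test, and whether an amine or a carboxylic acid there would do the same. They also leave open how this methyl would read on the core of compound 2, which keeps the pyridin-4-yl group.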